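Amide nitrogen substituent and tolerated concentration

This account rests on a few compounds, and the source may have more. Where it says the series, first, only, none or still open, it means among the compounds named here.

In an ADME assay on LLC-MK2 cells (Macaca mulatta) for cytotoxicity, read by spectrophotometry and crystal violet staining, with a stated time of 4 days (a lower number here means that less compound is tolerated, a higher number that more compound is tolerated), compound 2 `CC(C)n1ncc2c(C(=O)Nc3ccncc3)cc(-c3cccs3)nc21` gives 6300 nM, the lowest of the two numbers shown. Compound 3 `CC(C)n1ncc2c(C(=O)Nc3ccccn3)cc(C3CC3)nc21` gives 25000 nM, a gap beyond the usual scatter. Compound 1 `CC(C)n1ncc2c(C(=O)Nc3ccc(F)cc3)cc(-c3ccco3)nc21` gives > 200000 nM, which is a limit of the assay and not a number; its reading sits at the limit of > 200000 nM in this assay, at which 1 of the 3 values shown sits. For the measured compounds named here, none of these three pairs differs in a single place, so each pair is read only by its two values and no step is assigned to a single change.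

Compound 4 `CC(C)n1ncc2c(C(=O)Nc3ccccc3F)cc(-c3cccs3)nc21` differs from compound 2 by 2-fluorophenyl in place of pyridin-4-yl on an amide-type nitrogen. Compound 1 sits at the limit but differs from compound 2 in more than one place, so its reading cannot be tied to the amide-type nitrogen alone. In this assay a step upward, toward more tolerated compound, of moderate size is expected for compound 4, and a limit reading is possible. The estimate for compound 4 is 20000 nM, with a range from 5000 nM to 120000 nM. The expected step from compound 2 to compound 4 is a 3.2-fold higher number from compound 2 to compound 4 (0.50 log units; beyond the scatter).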

Compound 4, half-maximal cytotoxic concentration: 50000 nM
Compound 4: the middle estimate sits 2.5-fold (0.40 log units) below what was measured; the measured number falls inside the stated range.
By their numbers in this assay, from the lowest: compound 2; then compounds 3 and 4 (each within the scatter of the next). At a limit, above all of these: compound 1.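

In this assay, the amide-type nitrogen is the only place among the compounds shown where a single change can be read: 2-fluorophenyl in place of pyridin-4-yl gives a 7.9-fold higher number from compound 2 to compound 4 (0.90 log units; beyond the scatter). The change removes the ring nitrogen and its hydrogen-bond acceptor and brings in a carbon-only ring with fluorine, so these differences travel together and this step cannot separate them. Compound 4 gives a number and does not reach the limit of the assay: the limit of > 200000 nM in this assay, at which 1 of the 4 values shown sits.

A plain phenyl or a simple alkyl amine-bearing chain on the same amide-type nitrogen would be needed to show which part of the change goes with the step. All other pairs differ in more than one place and cannot be read as steps, so the contributions of the remaining substituents stay open.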